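From Hydroxy to Dimethylamino on Compound 3

This account rests on a few compounds, and the source may have more. Where it says the series, first, only, none or still open, it means among the compounds named here.

Of the compounds shown here, three sharing one core have been tested in a functional assay on B16-F10 cells (Mus musculus) for antiproliferative activity, read by CCK-8 assay, with a stated time of 48 h; on this read-out higher numbers stand for weaker inhibition and lower numbers for stronger inhibition. For compound 1 (`COc1ccc(/C=C\c2cc(OC)c(OC)c(OC)c2)cc1OCc1ccc(CN2CCCCC2C(=O)O)cc1`) the value > 10000 nM is a limit and not a number. For compound 2 (`COc1ccc(/C=C\c2cc(OC)c(OC)c(OC)c2)cc1OCc1ccc(CN[C@H](C(=O)O)[C@H](C)O)cc1`) the value > 10000 nM is likewise a limit. Going by the values given here, compound 3 (`COc1ccc(/C=C\c2cc(OC)c(OC)c(OC)c2)cc1OCc1ccc(CNCCO)cc1`) gives 6600 nM and this is the only true number among the three.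

The change to compound 4 (`COc1ccc(/C=C\c2cc(OC)c(OC)c(OC)c2)cc1OCc1ccc(CNCCN(C)C)cc1`) is dimethylamino in place of hydroxy on a saturated chain carbon, two bonds along the chain from an amine nitrogen and it turns 2-hydroxyethyl into 2-(dimethylamino)ethyl. Among the compounds with values here, three measured steps concern the same amine substituent. They are an at least 1.5-fold lower number from compound 1 to compound 3 (0.18 log units; that floor lies within the scatter) and an at least 1.5-fold lower number from compound 2 to compound 3 (0.18 log units; that floor lies within the scatter) and both sizes are only floors, which lie within the scatter. The third is a step that the two limits leave unreadable from compound 1 to compound 2 and it gives no size at all. None of these steps exchanges the hydroxy itself, so none sizes the new change directly.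

The expectation therefore starts from compound 3 at 6600 nM and allows no clear shift in this assay in either direction. The expected step is a 1.3-fold lower number from compound 3 to compound 4 (0.12 log units; within the scatter) and it is not expected to pass beyond the scatter. In this assay the estimate for compound 4 is 5000 nM with an expected range from 1500 nM to 10000 nM around it.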

Compound 4, half-maximal inhibitory concentration: > 10000 nM
Compound 4 ended at the assay's limit; the forecaster's own chance of this, stated with the estimate: 15%; at least 2.0-fold (0.30 log units) between middle value and limit.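

In this assay compound 4 gives > 10000 nM, which is a limit of the assay and not a number. Going by these compounds alone, this is the first exchange of the hydroxy itself, with dimethylamino taking its place on a saturated chain carbon, two bonds along the chain from an amine nitrogen, and it gives an at least 1.5-fold higher number from compound 3 to compound 4 (0.18 log units; that floor lies within the scatter), so the size of the step remains open beyond that floor. Compound 3, at 6600 nM, therefore remains the only compound in the series with a true number, and the exchange of 2-hydroxyethyl for 2-(dimethylamino)ethyl did not yield a second one: the limit of > 10000 nM in this assay, at which 3 of the 4 values shown sit.

The steps that link compound 4 to compound 1 and compound 2 cannot be read. From the compounds shown here alone, it remains open whether methoxy, a primary amino group or a longer chain ending in hydroxy at this place would give a true number in this assay, and how far any of them would lie from compound 3.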